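Amide substituent swap on the thiophene carboxamide series

This account rests on a few compounds, and the source may have more. Where it says the series, first, only, none or still open, it means among the compounds named here.

Compound 1 `CCNC(=O)c1cc(-c2cnn3cc(-c4cnn(C)c4)cnc23)cs1` gives 129 nM in an assay for inhibition of MAP/microtubule affinity-regulating kinase 3 (Homo sapiens), read by HTRF, with a stated time of 2 h; a higher number here means a weaker inhibitor, a lower number a stronger inhibitor. Compound 2 `Cn1cc(-c2cnc3c(-c4csc(C(=O)NC(CO)C5CC5)c4)cnn3c2)cn1` gives 9 nM in this assay, the lowest of the two numbers shown, reached by a 14-fold lower number from compound 1 to compound 2 (1.16 log units; beyond the scatter). Compound 3 `Cn1cc(-c2cnc3c(-c4csc(C(=O)N[C@@H]5CCC[C@H]5O)c4)cnn3c2)cn1` differs from compound 2 by a group of 6 heavy atoms (5 carbon, 1 oxygen; one five-membered non-aromatic ring of carbon only) in place of a group of 6 heavy atoms (5 carbon, 1 oxygen; one three-membered non-aromatic ring of carbon only), on an amide-type nitrogen; the two have the same atoms, joined differently. Within the data shown here, no measured step bears directly on this change, as the only step known, from compound 1 to compound 2, replaces a different group. The expected step from compound 2 to compound 3 is therefore a 1.7-fold higher number from compound 2 to compound 3 (0.22 log units; within the scatter), within the scatter. Compound 3 is estimated at 15 nM, range 5 nM to 45 nM.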

Compound 3, half-maximal inhibitory concentration: 10 nM
Estimate against measurement, compound 3: 1.5-fold (0.18 log units) above, and the stated range covers the measured number.
By their numbers in this assay, from the lowest: compounds 2 and 3 (each within the scatter of the next); then compound 1.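

On the amide-type nitrogen, the large drop also holds for 2-hydroxycyclopentyl in place of ethyl, with a 13-fold lower number from compound 1 to compound 3 (1.11 log units; beyond the scatter) as the step. The three-membered ring of compound 2 is therefore not required for the low number, since a 1.1-fold higher number from compound 2 to compound 3 (0.05 log units; within the scatter) leaves the five-membered ring level with it. No supporting data explain this result.

The compounds shown leave open what the oxygen contributes, which a plain cyclopentyl or an amine on the same ring would test. From the compounds shown here alone, the weight of the two defined stereocentres of 2-hydroxycyclopentyl also remains open.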